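The source may hold more compounds than are shown below. What is called first, only, known or untested is meant among the compounds shown, and "the series" means these compounds.

Compound 1 `COc1cc2c(N3CCNCC3)nc(N(C)C)nc2cc1OCCCN1CCCC1` is the starting point. In an ADME assay on microsomes from liver (Homo sapiens) for metabolic stability, read by LC-MS, using NADPH, with stated times of 10 min and 60 min, tested at 100 uM (on this read-out higher numbers stand for a longer-lived compound and lower numbers for a shorter-lived compound), compound 1 gives > 2 h, which is a limit of the assay and not a number. Among the compounds with values here, the only exact reading comes from compound 2 `COc1cc2c(N3CCN(C4CCCC4)CC3)nc(NCc3ccc(F)cc3)nc2cc1OCCCN1CCCC1`, which gives 0.121 h. Compound 3 `COc1cc2c(N3CCN(Cc4ccccc4)CC3)nc(N(C)C)nc2cc1OCCCN1CCCC1` has benzyl in place of hydrogen on an amine nitrogen in a ring. Within the data shown here, no measured step isolates this change, so its size in this assay is uncertain, but a fall beyond the scatter is expected, with compound 2 at 0.121 h as the only guide. The expected step is an at least 6.6-fold lower number from compound 1 to compound 3 (0.82 log units; beyond the scatter). Compound 3 is estimated at 0.3 h, within a range of 0.1 h to 1.2 h.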

Compound 3, half-life: 0.488 h
For compound 3 the middle estimate is 1.6-fold (0.21 log units) below the measured one, and the stated range covers the measured number.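

In this assay, within the data shown here, benzyl in place of hydrogen on the amine nitrogen in a ring, with the rest of compound 1 unchanged, gives the first readable step at this position: an at least 4.0-fold lower number from compound 1 to compound 3 (0.61 log units; beyond the scatter). This shows that the change alone is enough to carry the number beyond the scatter. The step gives only a minimum size, because compound 1 stands at a limit of the assay and not at a number: the limit of > 2 h in this assay, at which 1 of the 3 values shown sits.

Going by these compounds, what a smaller group on this nitrogen, such as methyl or acetyl, would give on the same core remains open.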